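Adding a Third Methyl to the Benzyl Ether

The source may report more compounds than this note shows. Statements on the series, on what has been measured and on what is new or still open speak of the compounds shown alone.

Measured so far:
compound 1, `Cc1ccccc1COc1cc(NC(=O)c2ccccc2)ccc1N(C)S(C)(=O)=O`, gives 176000 nM
compound 2, `Cc1cccc(C)c1COc1cc(NC(=O)C2CCCCC2)ccc1N(C)S(C)(=O)=O`, gives 39400 nM
compound 3, `Cc1cccc(C)c1COc1cc(NC(=O)c2ccccc2)ccc1N(C)S(C)(=O)=O`, gives 16200 nM

All three were tested in a functional assay on cells (Homo sapiens) for cytotoxicity, read by MTT assay, with a stated time of 72 h; a higher number here means a weaker inhibitor, a lower number a stronger inhibitor. The change methyl in place of hydrogen on an aromatic carbon brought an 11-fold lower number from compound 1 to compound 3 (1.04 log units; beyond the scatter). A second step, a 2.4-fold lower number from compound 2 to compound 3 (0.39 log units; beyond the scatter), is modest. The difference between the cores of compound 2 and compound 1 is not broken down here.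

Compound 4, `Cc1cc(C)c(COc2cc(NC(=O)C3CCCCC3)ccc2N(C)S(C)(=O)=O)c(C)c1`, is not yet measured. It differs from compound 2 by methyl in place of hydrogen on an aromatic carbon, the same kind of change as from compound 1 to compound 3, not the same: in compound 3 the methyl sits ortho to a large group and meta to a methyl group, while in compound 4 it sits meta to two methyl groups and para to a large group. The step expected in this assay is a 2.0-fold lower number from compound 2 to compound 4 (0.29 log units; within the scatter), smaller, because an 11-fold lower number from compound 1 to compound 3 (1.04 log units; beyond the scatter) was measured for a methyl entering at a different place. Compound 4 is therefore expected to give 20000 nM, estimated between 8000 nM and 50000 nM.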

Compound 4, half-maximal inhibitory concentration: 18500 nM
Estimate against measurement, compound 4: 1.1-fold (0.03 log units) above; measured number inside the range.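

In this assay, the added methyl gives a 2.1-fold lower number from compound 2 to compound 4 (0.33 log units; beyond the scatter), so the number falls in the same direction as in the earlier methyl step. The size of the step, however, does not carry over from one core to the other: the same change on two cores in this assay, an 11-fold lower number (1.04 log units; beyond the scatter) from compound 1 to compound 3 and a 2.1-fold lower number (0.33 log units; beyond the scatter) from compound 2 to compound 4, 5.1-fold (0.71 log units) apart, beyond the scatter of two such steps

This does not show whether the place of the methyl or the rest of the molecule accounts for the gap, as the methyl enters at a different place in each pair and the two pairs also differ at the carbonyl, with phenyl in one and cyclohexyl in the other. The compounds shown leave open whether an ethyl or a methoxy group at the place of the new methyl would lower the number further. They also leave open how the same methyl would act with a longer chain in place of cyclohexyl on the carbonyl.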